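A methoxy group added to the benzyl of compound 2

This account rests on a few compounds, and the source may have more. Where it says the series, first, only, none or still open, it means among the compounds named here.

In a functional assay on A375P cells (Homo sapiens) for inhibition, read by MTT assay, with a stated time of 24 h (on this read-out higher numbers stand for weaker inhibition of growth and lower numbers for stronger inhibition of growth), compound 1 `O=C1CC(c2ccc(NC(=O)c3ccc(Cl)c(C(F)(F)F)c3)cc2)=Nc2cnn(Cc3ccccc3)c2N1` gives 13100 nM and compound 2 `O=C1CC(c2ccc(NC(=O)Nc3ccc(Cl)c(C(F)(F)F)c3)cc2)=Nc2cnn(Cc3ccccc3)c2N1` gives 1190 nM, so compound 2 has the lower number of the two and stronger inhibition of growth. Among the measured compounds shown here, the only measured step, an 11-fold lower number from compound 1 to compound 2 (1.04 log units; beyond the scatter), is large, but it comes from a change on the carbonyl carbon. Compound 3 `COc1ccc(Cn2ncc3c2NC(=O)CC(c2ccc(NC(=O)Nc4ccc(Cl)c(C(F)(F)F)c4)cc2)=N3)cc1` instead differs from compound 2 at the benzyl group: methoxy in place of hydrogen on an aromatic carbon, which turns benzyl into 4-methoxybenzyl. For the measured compounds named here, no measured pair changes this part of the molecule, so the large step offers no guide to the size or direction of this one. In this assay, no step beyond the usual scatter is therefore expected, though with wide uncertainty. The expected change is a 1.1-fold higher number from compound 2 to compound 3 (0.04 log units; within the scatter). For compound 3 the estimated value is 1300 nM, with an expected range from 450 nM to 3800 nM.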

Compound 3, concentration for 50% growth inhibition: 3930 nM
The estimate for compound 3 lay 3.0-fold (0.48 log units) below the measured number, outside the stated range (above it).
By their numbers in this assay, from the lowest: compound 2; then compound 3; then compound 1.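

In this assay, the benzyl group proves to be a place where a small addition counts: turning it into 4-methoxybenzyl gives a 3.3-fold higher number from compound 2 to compound 3 (0.52 log units; beyond the scatter), which means weaker inhibition of growth. Among the compounds shown here, the earlier pair varied only the group on the carbonyl carbon, so this is the first sign that the far end of the molecule also affects the result, and here the added methoxy works against growth inhibition. Nothing available explains why this single change raises the number.

The compounds shown leave open whether this rise is specific to methoxy or would also appear with a hydroxyl group, a fluorine atom or a longer ethoxy chain at the same place. They also leave open whether methoxy at another place on the ring would behave the same way.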